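The source may hold more compounds than are shown below. What is called first, only, known or untested is meant among the compounds shown, and "the series" means these compounds.

Measured so far:
Compound 1, `CC(C)[C@H](NC(=O)c1cc(Cl)ccc1O)C(=O)Nc1ccc(Cl)cc1`, in a functional assay on K562 cells (Homo sapiens) for cytotoxicity, with a stated time of 72 h (on this read-out lower numbers stand for stronger inhibition and higher numbers for weaker inhibition), gives > 20000 nM, which is a limit of the assay and not a number.
Compound 2, `C[C@H](NC(=O)c1ccc(Cl)cc1O)C(=O)Nc1ccc(C(F)(F)F)cc1`, gives > 12500 nM in this assay, again a limit rather than a number.
Compound 3, `CC(C)[C@H](NC(=O)c1cc(Cl)ccc1O)C(=O)Nc1ccc(C(F)(F)F)cc1`, gives 4500 nM in this assay.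

Compound 1 differs from compound 3 only by chloro in place of trifluoromethyl on an aromatic carbon, and that change brought an at least 4.4-fold higher number from compound 3 to compound 1 (0.64 log units; beyond the scatter). Compound 4, `C[C@H](NC(=O)c1ccc(Cl)cc1O)C(=O)Nc1ccc(Cl)cc1`, has not yet been measured; it differs from compound 2 by chloro in place of trifluoromethyl on an aromatic carbon, the same change at the same place. The cores of compound 2 and compound 3 differ, and that difference is not broken down here. Because compound 2 already sits at the limit (the limit of > 12500 nM in this assay, at which 1 of the 3 values shown sits), and the same change weakened compound 3 in an at least 4.4-fold higher number from compound 3 to compound 1 (0.64 log units; beyond the scatter), compound 4 is expected to be no stronger, with an expected step that the limit leaves unreadable from compound 2 to compound 4. Compound 4 is therefore estimated at 40000 nM in this assay, expected between 12500 nM and 150000 nM, and most likely reported only as a limit again.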

Compound 4, half-maximal inhibitory concentration: > 10000 nM
Compound 4: no number, only a limit; the forecaster's own chance of this, stated with the estimate: 85%; the middle value is on the limit's open side.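

Compound 2 and compound 4 each give only a limit in this assay, not a number, so the step between them cannot be read. Going by these compounds, it remains open whether chloro in place of trifluoromethyl acts on the core of compound 2 as it does on the core of compound 3.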